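Swapping a Methyl for Hydrogen on Compound 2

A few compounds are considered here, and "the series" means these few. Any claim that something is new, unique, unknown or untested is made for them only; others in the source may bear on it.

Measured in a functional assay on Calu-1 cells (Homo sapiens) for cytotoxicity, read by resazurin assay, with a stated time of 72 h; a lower number here means a stronger inhibitor, a higher number a weaker inhibitor:
- Compound 1 `COc1cc(/C=C/C(=O)OCCCCOc2no[n+]([O-])c2S(=O)(=O)c2ccccc2)ccc1O`: 410 nM
- Compound 2 `COc1cc(/C=C/C(=O)OCCCO[N+](=O)[O-])ccc1OCCCO[N+](=O)[O-]`: 1420 nM
- Compound 3 `COc1cc(/C=C/C(=O)OCCCO[N+](=O)[O-])ccc1O`: > 50000 nM, a limit and not an exact number

Of the two exact numbers, compound 2 has the higher one, and the gap down to compound 1 lies beyond the scatter.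

Compound 4 `O=C(/C=C/c1ccc(OCCCO[N+](=O)[O-])c(O)c1)OCCCO[N+](=O)[O-]` differs from compound 2 at one place: hydrogen in place of methyl on an oxygen on an aromatic ring. For the measured compounds named here, the only measured step, an at least 35-fold higher number from compound 2 to compound 3 (1.54 log units; beyond the scatter), is large, but it removes 3-(nitrooxy)propyl, a group that compound 4 keeps. It therefore bears only loosely on this change. In this assay, the expected step, a 1.4-fold higher number from compound 2 to compound 4 (0.15 log units; within the scatter), is small and leans towards a higher number. For compound 4 the estimated value is 2000 nM, with an expected range from 600 nM to 8000 nM.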

Compound 4, half-maximal inhibitory concentration: 12500 nM
Estimate against measurement, compound 4: 6.3-fold (0.80 log units) below; the whole stated range lies below it.
By their numbers in this assay, from the lowest: compound 1; then compound 2; then compound 4. At a limit, above all of these: compound 3.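

Swapping methoxy for hydroxy on the aromatic ring, with both 3-(nitrooxy)propyl groups kept, is a modest change in this assay, but not a silent one: an 8.8-fold higher number from compound 2 to compound 4 (0.94 log units; beyond the scatter). Losing a single carbon here is enough to carry the number beyond the scatter, so this oxygen's methyl is not a spectator. Nothing measured here gives the reason for this step.

On these data alone, whether an ethoxy group or a longer chain on this oxygen would keep the lower number remains open. So does the effect of an amine at this place.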